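Iodo in Place of Acetyl: Estimating Compound 4

The source may hold more compounds than are shown below. What is called first, only, known or untested is meant among the compounds shown, and "the series" means these compounds.

Measured so far:
- compound 1, `CC(C)c1ccccc1NC(=O)N[C@H](C)c1ccccc1`: 103%
- compound 2, `C[C@@H](NC(=O)Nc1ccccc1C(C)(C)C)c1ccccc1`: 100%
- compound 3, `CC(=O)c1ccccc1NC(=O)N[C@H](C)c1ccccc1`: 96%

In an ADME assay on the whole organism with Oryza sativa as the target, tested at 0.1 uM (on this read-out higher numbers stand for a weaker effect at the one concentration tested and lower numbers for a stronger effect), these three compounds give numbers that are close together. Compound 3 has the lowest of the three, but the steps reaching it are small: a number 7 percentage points lower from compound 1 to compound 3 (within the scatter) and a number 4 percentage points lower from compound 2 to compound 3 (within the scatter), both within the usual scatter, so no real difference between the three has been shown.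

The next compound, compound 4 with structure `C[C@@H](NC(=O)Nc1ccccc1I)c1ccccc1`, differs from compound 3 in one place: iodo in place of acetyl on an aromatic carbon. For the measured compounds named here, two measured steps bear on this. They also exchange the group at this aromatic carbon: a number 7 percentage points lower from compound 1 to compound 3 (within the scatter) and a number 4 percentage points lower from compound 2 to compound 3 (within the scatter). Neither exchange at that carbon moved the read-out beyond the scatter, and iodo is a group of a single heavy atom, so no step beyond the scatter is expected here either.

Compound 4 is therefore estimated at 99%, with a range from 88% to 110%. This estimate means an expected step of a number 3 percentage points higher from compound 3 to compound 4 (within the scatter), within the scatter.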

Compound 4, a percentage reported as activity, at one concentration (the size of the read-out at that concentration, not a potency): 100%
Compound 4: the middle estimate sits 1 percentage points below what was measured; low and high end bracket the measured number.
By their numbers in this assay, from the lowest: compounds 3, 2, 4 and 1 (each within the scatter of the next).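

On the aromatic carbon ortho to a large group, iodo now joins isopropyl, tert-butyl and acetyl, and in this assay the read-out separates it from none of them. The exchanges give a number 4 percentage points higher from compound 3 to compound 4 (within the scatter) and no change at the digits printed from compound 2 to compound 4 (within the scatter) and also a number 3 percentage points lower from compound 1 to compound 4 (within the scatter) so all four groups at this carbon remain within the scatter of their neighbours in the ranking. This holds even though acetyl, with 3 heavy atoms and 1 hydrogen-bond acceptor, gives way to iodo, with 1 heavy atom and 0 hydrogen-bond acceptors. The compounds shown leave open whether an amine or a carboxylic acid on this carbon would move the read-out beyond the scatter. Nothing measured here offers an explanation for these results.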